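A few compounds are considered here, and "the series" means these few. Any claim that something is new, unique, unknown or untested is made for them only; others in the source may bear on it.

Working notes on the series. Compound 1 `Cc1cccc(CSc2cc(Cl)c(C)cc2S(=O)(=O)/N=C(\N)n2nccc2-c2ccccc2)c1` gives 8000 nM in a functional assay on HeLa cells (Homo sapiens) for cytotoxicity, read by MTT assay, with a stated time of 72 h; on this read-out lower numbers stand for stronger inhibition and higher numbers for weaker inhibition. Compound 3 `Cc1cc(S(=O)(=O)/N=C(\N)n2nccc2-c2ccccc2)c(SCc2ccccc2)cc1Cl` gives 5000 nM in this assay, and the step of a 1.6-fold lower number from compound 1 to compound 3 (0.20 log units; within the scatter) lies within the scatter. Compound 2 `Cc1cc(-c2ccccc2)n(/C(N)=N/S(=O)(=O)c2cc(C)c(Cl)cc2SCc2cccc(C(F)(F)F)c2)n1` gives 98000 nM in this assay, the highest of the three numbers; its gaps to compound 1 and to compound 3 both lie beyond the scatter.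

Compound 4 `Cc1cccc(CSc2cc(Cl)c(C)cc2S(=O)(=O)/N=C(\N)n2nc(C)cc2-c2ccccc2)c1` has not been measured. It differs from compound 2 in one place: methyl in place of trifluoromethyl on an aromatic carbon. Within the data shown here, no measured step covers this exchange. Among the measured compounds shown here, the only measured step, a 1.6-fold lower number from compound 1 to compound 3 (0.20 log units; within the scatter), concerns a different methyl and lies within the scatter, so it says nothing about the trifluoromethyl. Compound 4 carries the 3-methylbenzyl of compound 1 together with the extra methyl on the core that compound 2 has and compound 1 lacks; compound 1 and compound 2 are separated by two changes, so how much of their gap belongs to the trifluoromethyl cannot be read from the numbers. The expected step of a 3.9-fold lower number from compound 2 to compound 4 (0.59 log units; beyond the scatter) is taken as a lowering of the number, but with wide uncertainty. Compound 4 is therefore estimated at 25000 nM in this assay, expected to fall between 7000 nM and 90000 nM.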

Compound 4, half-maximal inhibitory concentration: 155000 nM
The estimate for compound 4 lay 6.2-fold (0.79 log units) below the measured number, and the stated range ends below it.
By their numbers in this assay, from the lowest: compounds 3 and 1 (each within the scatter of the next); then compounds 2 and 4 (each within the scatter of the next).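

In this assay, exchanging 3-(trifluoromethyl)benzyl for 3-methylbenzyl gives a 1.6-fold higher number from compound 2 to compound 4 (0.20 log units; within the scatter), so this position on the benzyl ring tolerates the change from trifluoromethyl to methyl with no separable effect on the number, at least when the core carries its extra methyl. Among these compounds, the large change lies elsewhere: adding that methyl to an aromatic carbon of the core, with the 3-methylbenzyl held constant, gives a 19-fold higher number from compound 1 to compound 4 (1.29 log units; beyond the scatter), the first step beyond the scatter that has a single structural change behind it, whereas the earlier methyl-to-hydrogen step on the benzyl ring stayed within the scatter. Nothing available gives a reason for either the flat step on the benzyl ring or the large step on the core.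

The compounds shown leave open whether the core methyl costs as much alongside 3-(trifluoromethyl)benzyl or unsubstituted benzyl, since each of these appears with only one form of the core. They also leave open how an amine or a longer chain at that aromatic carbon of the core would read.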